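Dihydropyridine ester variation: from a chloroethyl to a dimethoxybenzyl ester

A few compounds are considered here, and "the series" means these few. Any claim that something is new, unique, unknown or untested is made for them only; others in the source may bear on it.

Measured compounds:
compound 1, `CCCC1=C(C(=O)OCC)C(c2cccc([N+](=O)[O-])c2)C(C(=O)OCC)=C(C)N1`, 105 nM
compound 2, `CCOC(=O)C1=C(C)NC(COC)=C(C(=O)OC)C1c1cccc([N+](=O)[O-])c1`, 96 nM
compound 3, `COC(=O)C1=C(C)NC(C)=C(C(=O)OCCCl)C1c1cccc([N+](=O)[O-])c1`, 22 nM

Three compounds sharing one core were tested in a functional assay on HEK293 cells for antagonist activity at Voltage-dependent L-type calcium channel subunit alpha-1D (Rattus norvegicus), read by FLIPR; on this read-out higher numbers stand for weaker inhibition and lower numbers for stronger inhibition. Compound 1 gives 105 nM, and compound 2 gives 96 nM. Compound 3 stands lowest of the three numbers: its value of 22 nM lies beyond the scatter from both compound 2 and compound 1, so compound 3 is the strongest inhibitor among those measured.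

Compound 4, `COC(=O)C1=C(C)NC(C)=C(C(=O)OCc2ccc(OC)c(OC)c2)C1c1cccc([N+](=O)[O-])c1`, is not yet measured. It differs from compound 3 in one place: 3,4-dimethoxyphenyl in place of chloromethyl on a saturated chain carbon bound to an oxygen next to a carbonyl group. Among the compounds with values here, no step between two measured compounds describes a change of this kind, so nothing among the measured values speaks directly for or against it. With only compound 3 as a reference point in this assay, the expectation is a step of no more than the usual scatter, leaning, if anywhere, towards a slightly lower number. The expected step from compound 3 to compound 4 is a 1.5-fold lower number from compound 3 to compound 4 (0.17 log units; within the scatter). Compound 4 is therefore estimated at 15 nM, with a range from 5 nM to 60 nM.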

Compound 4, half-maximal inhibitory concentration: 117 nM
For compound 4 the middle estimate is 7.8-fold (0.89 log units) below the measured one; measured number outside the range, above it.
By their numbers in this assay, from the lowest: compound 3; then compounds 2, 1 and 4 (each within the scatter of the next).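

Within the data shown here, at this position, on a saturated chain carbon bound to an oxygen next to a carbonyl group, the exchange of chloromethyl for 3,4-dimethoxyphenyl gives the first one-place comparison in this assay, and it reads as a 5.3-fold higher number from compound 3 to compound 4 (0.73 log units; beyond the scatter). The position is thus not indifferent to what stands on that carbon: the 3,4-dimethoxybenzyl ester, with the six-membered aromatic ring of its entering group, goes with weaker inhibition than the 2-chloroethyl ester. Nothing measured here accounts for this step.

The compounds shown leave open whether the step goes with the aromatic ring itself or with its two methoxy groups, a question that a plain benzyl ester would address. They also leave open how an ester carrying an amine at the end of a longer chain would read at this position, and whether the same exchange would give a step of similar size with the other ester groups of the shared core.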